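A few compounds are considered here, and "the series" means these few. Any claim that something is new, unique, unknown or untested is made for them only; others in the source may bear on it.

In a physicochemical assay for solubility, read by nephelometry, in phosphate buffer, measured as kinetic solubility, at pH 6.5 (on this read-out higher numbers stand for higher solubility and lower numbers for lower solubility), compound 2 `CCOC(=O)C1=C(C)N/C(=C/c2cc(C)n(-c3ccc(OC)cc3)c2C)C1=O` gives 3.1 ug/mL. Compound 1 `CCOC(=O)C1=C(C)N/C(=C/c2cc(C)n(-c3cccc(C(F)(F)F)c3)c2C)C1=O` gives 2.1 ug/mL and compound 3 `CCOC(=O)C1=C(C)N/C(=C/c2cc(C)n(-c3cccnc3)c2C)C1=O` gives 25 ug/mL, so compound 2 stands between them, its gap to compound 1 within the scatter and its gap to compound 3 beyond it. Compound 4 `CCOC(=O)C1=C(C)N/C(=C/c2cc(C)n(-c3ccc(CN4CCCCC4)cc3)c2C)C1=O` changes compound 2 by (piperidin-1-yl)methyl in place of methoxy on an aromatic carbon. For the measured compounds named here, two measured steps bear on swapping the group on this ring: a 1.5-fold higher number from compound 1 to compound 2 (0.17 log units; within the scatter), and an 8.1-fold higher number from compound 2 to compound 3 (0.91 log units; beyond the scatter), where the entering ring, like the entering group here, contains a nitrogen. A rise beyond the scatter is therefore expected in this assay, of about a 9.7-fold higher number from compound 2 to compound 4 (0.99 log units; beyond the scatter). Compound 4 is estimated at 30 ug/mL, with a range from 6 ug/mL to 120 ug/mL.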

Compound 4, solubility: 12.5 ug/mL
Beside the measured number, compound 4's estimate is 2.4-fold (0.38 log units) above it, and the stated range covers the measured number.
By their numbers in this assay, from the lowest: compounds 1 and 2 (each within the scatter of the next); then compounds 4 and 3 (each within the scatter of the next).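

With the phenyl ring kept, (piperidin-1-yl)methyl in place of methoxy on an aromatic carbon, para to a large group, gives a 4.0-fold higher number from compound 2 to compound 4 (0.61 log units; beyond the scatter) in this assay, so changing this one group can move the number beyond the scatter. The earlier steps shown here beyond the scatter replaced the whole ring. Nothing shown accounts for this rise. The entering group brings both a nitrogen and a ring, and the compounds shown cannot separate the two. Cyclohexylmethyl, which has the ring without the nitrogen, and dimethylaminomethyl, which has the nitrogen without the ring, remain open at this place.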